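Cyclobutyl to ethyl on the side-chain amide of compound 1

The source may hold more compounds than are shown below. What is called first, only, known or untested is meant among the compounds shown, and "the series" means these compounds.

Within the data shown here, compound 1 `CC[C@H]1OC(=O)[C@H](C)[C@@H](O[C@H]2C[C@@](C)(OC)[C@@H](OCCCNC(=O)C3CCC3)[C@H](C)O2)[C@H](C)[C@@H](O[C@@H]2O[C@H](C)C[C@H](N(C)C)[C@H]2O)[C@](C)(O)C[C@@H](C)CN(C)[C@H](C)[C@@H](O)[C@]1(C)O` is the lower of the two compounds measured so far in a physicochemical assay for lipophilicity, read by HPLC, measured as chromatographic lipophilicity, at pH 7.4; on this read-out higher numbers stand for higher lipophilicity and lower numbers for lower lipophilicity: compound 1 gives 2.62. Among the measured compounds shown here, the second measured compound, compound 2 `CCCCC(=O)NCCCO[C@@H]1[C@@H](C)N(C)C[C@H](C)C[C@@](C)(O)[C@H](O[C@@H]2O[C@H](C)C[C@H](N(C)C)[C@H]2O)[C@@H](C)[C@H](O[C@H]2C[C@@](C)(OC)[C@@H](O)[C@H](C)O2)[C@@H](C)C(=O)O[C@H](CC)[C@@]1(C)O`, gives 3.74 in this assay, a gap beyond the usual scatter; no single-point step connects compound 2 to compound 1, so only the two values themselves can be compared.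

Compound 3 `CCC(=O)NCCCO[C@H]1[C@H](C)O[C@@H](O[C@H]2[C@H](C)[C@@H](O[C@@H]3O[C@H](C)C[C@H](N(C)C)[C@H]3O)[C@](C)(O)C[C@@H](C)CN(C)[C@H](C)[C@@H](O)[C@](C)(O)[C@@H](CC)OC(=O)[C@@H]2C)C[C@@]1(C)OC` has not yet been measured. It differs from compound 1 in one place: ethyl in place of cyclobutyl on a carbonyl carbon. The group that enters is smaller than the group that leaves, so a shift toward lower lipophilicity is expected, probably of moderate size rather than within the scatter. The step from compound 1 to compound 3 is estimated at a number 0.62 log units lower from compound 1 to compound 3 (beyond the scatter) in this assay. Compound 3 is therefore expected to give about 2, with a range from 1.5 to 2.5.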

Compound 3, distribution coefficient: 2.54
Beside the measured number, compound 3's estimate is 0.54 log units below it; the measured number lies above the stated range.
By their numbers in this assay, from the lowest: compounds 3 and 1 (each within the scatter of the next); then compound 2.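

Notes on the side-chain amide: with ethyl in place of cyclobutyl on the carbonyl carbon, this assay gives a number 0.08 log units lower from compound 1 to compound 3 (within the scatter), the first single-point step at this position in the series. On this read-out, cyclobutyl and ethyl cannot be told apart here, although the group that enters is the smaller one and carries no ring. No measurement available bears on why the two groups read alike.

Going by these compounds, whether that holds for other groups on the same carbonyl carbon, such as a longer chain like hexyl, a chain carrying an amine or a carboxylic acid, remains open. Also open, on these data alone, is whether the same change reads alike on a compound other than compound 1.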